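A few compounds are considered here, and "the series" means these few. Any claim that something is new, unique, unknown or untested is made for them only; others in the source may bear on it.

Measured compounds in a functional assay on HepG2 cells (Homo sapiens) for antiproliferative activity, read by MTT assay, with a stated time of 72 h; on this read-out lower numbers stand for stronger inhibition and higher numbers for weaker inhibition:
compound 1 `C=CC(=O)Nc1cc(Nc2nc(C)cc(-c3cn(C)c4ccccc34)n2)c(OC)cc1N(C)CCN(C)C` gives 12600 nM;
compound 2 `COc1cc(N(C)CCN(C)C)c(NC(=O)/C=C\C(C)C)cc1Nc1nccc(-c2cn(C)c3ccc(F)cc23)n1` gives 3920 nM;
compound 3 `C=CC(=O)Nc1cc(Nc2nc(C)cc(-c3cn(C)c4ccc(F)cc34)n2)c(OC)cc1N(C)CCN(C)C` gives 4280 nM.

Compound 3 holds the second highest of the three numbers. Within the data shown here, its nearest neighbour is compound 2, whose value lies within the usual scatter of that of compound 3; compound 1 is the furthest, and the single-site step a 2.9-fold lower number from compound 1 to compound 3 (0.47 log units; beyond the scatter) is the only step in this set that reaches beyond the scatter.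

Compound 4 `COc1cc(N(C)CCN(C)C)c(NC(=O)/C=C\C(C)C)cc1Nc1nc(C)cc(-c2cn(C)c3ccc(F)cc23)n1` differs from compound 3 in one place: 3-methylbut-1-en-1-yl in place of vinyl on a carbonyl carbon. Among the measured compounds shown here, no measured pair differs in exactly this change, so no step bears on it directly. For the measured compounds named here, compound 2 shares with compound 4 the 3-methylbut-1-en-1-yl group on the carbonyl carbon but differs from it elsewhere as well; its value and that of compound 3 lie within the scatter of each other, and this is the only guide available. The step of a 1.1-fold higher number from compound 3 to compound 4 (0.02 log units; within the scatter) is therefore expected to stay within the scatter, with no settled direction. Compound 4 is estimated at 4500 nM, with a range from 1800 nM to 11000 nM.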

Compound 4, half-maximal inhibitory concentration: 14000 nM
For compound 4 the middle estimate is 3.1-fold (0.49 log units) below the measured one, and the stated range ends below it.
By their numbers in this assay, from the lowest: compounds 2 and 3 (each within the scatter of the next); then compounds 1 and 4 (each within the scatter of the next).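

In this assay, among these compounds, the step of a 3.3-fold higher number from compound 3 to compound 4 (0.51 log units; beyond the scatter) gives the first direct reading at the carbonyl carbon: 3-methylbut-1-en-1-yl in place of vinyl raises the number beyond the scatter. Among the compounds shown here, the step of a 3.6-fold higher number from compound 2 to compound 4 (0.55 log units; beyond the scatter) shows that, with 3-methylbut-1-en-1-yl held in place, the single change separating these two compounds also raises the number beyond the scatter. Both single changes therefore lead upward to compound 4, a fact that the close values of compound 2 and compound 3 did not reveal, and no measurement at hand accounts for either step.

Open, as far as these compounds go, is how an amine or a shorter alkenyl chain on the carbonyl carbon would read against vinyl and 3-methylbut-1-en-1-yl. Also open, from the compounds shown here alone, is whether the change at the carbonyl carbon reads the same on the core of compound 1, which carries hydrogen in place of fluoro.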